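The source may report more compounds than this note shows. Statements on the series, on what has been measured and on what is new or still open speak of the compounds shown alone.

Working notes on the series.

Compound 1 `Cc1ccccc1-n1nc(C)c2c1NC(=O)[C@H](C)S[C@@H]2c1ccc(/C=C/c2ccccc2)cc1` carries a 2-phenylethenyl group on the shared core and, in an assay on isolated protein for agonist activity at Bile acid receptor (Homo sapiens), read by AlphaScreen, with a stated time of 30 min (on this read-out lower numbers stand for an effect already at smaller amounts and higher numbers for an effect only at larger amounts of compound), compound 1 gives "not active" (no number reported), so no single number is available for it. Two phenoxy-bearing relatives set the frame: in this assay compound 2 `Cc1nn(-c2ccccc2Cl)c2c1C(c1ccc(Oc3ccccc3)cc1)SC(C)C(=O)N2` gives 2700 nM, and in this assay compound 3 `COc1ccccc1-n1nc(C)c2c1NC(=O)[C@H](C)S[C@@H]2c1ccc(Oc2ccccc2)cc1` gives 3300 nM; these two values lie within the usual scatter of each other. Compound 4 `COc1ccc(Oc2ccc([C@H]3S[C@@H](C)C(=O)Nc4c3c(C)nn4-c3ccccc3C)cc2)cc1` is the untested member. It differs from compound 1 as follows: 4-methoxyphenoxy in place of 2-phenylethenyl on an aromatic carbon. As compound 1 has no number, no size of step can be read off; the change brings compound 4 toward the phenoxy pattern of compound 2 and compound 3, and the expectation is that a measurable value appears. Compound 4 is estimated to give 3000 nM, within 800 nM to 12000 nM.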

Compound 4, half-maximal effective concentration: 2200 nM
Beside the measured number, compound 4's estimate is 1.4-fold (0.13 log units) above it; the measured number falls inside the stated range.
By their numbers in this assay, from the lowest: compounds 4, 2 and 3 (each within the scatter of the next).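

No step can be read between compound 1, which has no number, and compound 4. The compounds shown leave open how 4-methoxyphenoxy compares with phenoxy on an otherwise unchanged core. No further data bear on this result.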